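The compounds below may be only part of what the source reports. "The series", "measured", "known", "first", "only" and "open" are said of these compounds alone.

Three compounds have been measured in a functional assay on WI-38 VA13 cells (Homo sapiens) for cytotoxicity; on this read-out higher numbers stand for an effect only at larger amounts of compound and lower numbers for an effect already at smaller amounts:

Compound 1 `Cn1nccc1C(=O)Nc1ccc2nc(NC(=O)C3CCCCC3)sc2c1` gives 0.58 ug/mL in this assay.
Compound 2 `Cc1[nH][n+](C)c(C)c1C(=O)Nc1ccc2nc(NC(=O)C3CCCCC3)sc2c1` gives 0.012 ug/mL in this assay.
Compound 3 `CCCOC(=O)Nc1nc2ccc(NC(=O)c3c(Cl)cccc3Cl)cc2s1` gives 0.0025 ug/mL in this assay.

Compound 3 stands lowest of these three numbers; its nearest neighbour is compound 2 and its furthest is compound 1, and both gaps lie beyond the usual scatter of repeated measurements.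

Compound 4 `CCCCCNc1nc2ccc(NC(=O)c3c(Cl)cccc3Cl)cc2s1` has not yet been measured. It differs from compound 3 in one place: pentyl in place of propoxycarbonyl on a nitrogen on an aromatic ring.

Among the compounds with values here, only one measured step is available, a 48-fold lower number from compound 1 to compound 2 (1.68 log units; beyond the scatter), and it concerns a group on a carbonyl carbon in a different part of the shared core, not the nitrogen on the aromatic ring that changes here. It therefore does not speak directly to the present change; it only shows that a single change at one end of this core can move the number a great deal. Within the data shown here, no measured pair shows what pentyl in place of propoxycarbonyl at this nitrogen does. In compounds 1, 2 and 3 this nitrogen always carries a carbonyl, so compound 4 steps outside what has been seen.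

Given this, a moderate rise in the number from compound 3 is expected, namely an 8.0-fold higher number from compound 3 to compound 4 (0.90 log units; beyond the scatter), with a wide range around it. Compound 4 is estimated to give 0.02 ug/mL in this assay, expected to fall between 0.003 ug/mL and 0.15 ug/mL.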

Compound 4, half-maximal effective concentration: 0.27 ug/mL
Compound 4: middle estimate off by 14-fold (1.13 log units), on the low side, and the stated range ends below it.
By their numbers in this assay, from the lowest: compound 3; then compound 2; then compound 4; then compound 1.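

Within the data shown here, this is the first measured change at the nitrogen on an aromatic ring, and in this assay pentyl in place of propoxycarbonyl gives a 110-fold higher number from compound 3 to compound 4 (2.03 log units; beyond the scatter). This position is therefore as sensitive as the carbonyl carbon at the other end of the shared core, where a 48-fold lower number from compound 1 to compound 2 (1.68 log units; beyond the scatter) is also a large step beyond the scatter. The leaving and entering groups are close in heavy-atom count, but only propoxycarbonyl holds oxygen, a carbonyl and hydrogen-bond acceptors, so in this pair the lower number goes with the group that has them, and nothing available explains the link.

This single pair cannot separate the carbonyl from the rest of the group, and a butanoyl group, which keeps the carbonyl on a plain carbon chain, would speak to that point. Also open, as far as these compounds go, are how a free amine or a chain longer than pentyl on this nitrogen would read, and whether the step would keep its size with a different group on the other carbonyl of the shared core.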